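Methoxy in place of methyl: note on compound 3

The source may hold more compounds than are shown below. What is called first, only, known or untested is meant among the compounds shown, and "the series" means these compounds.

Compound 1 `COc1cc(OC)c(OC)cc1/C=C/C(=O)c1ccc(C)cc1` and compound 2 `COc1cc(OC)c(-c2cc(=O)c3cc(Cl)ccc3o2)cc1OC` have both been run in a functional assay, read by Griess assay, with a stated time of 2.5 h; a higher number here means a weaker inhibitor, a lower number a stronger inhibitor. Compound 1 gives 2.18 ug/mL, and compound 2 gives 2.15 ug/mL; the two numbers sit within the scatter of each other, so no order between them is read. Within the data shown here, no step between compounds differing in one place exists in this pair. Compound 3 `COc1ccc(C(=O)/C=C/c2cc(OC)c(OC)cc2OC)cc1` has not been measured. Against compound 1 it shows (methoxy in place of methyl on an aromatic carbon), the change sitting on an aromatic carbon of a six-membered aromatic ring of carbon only. With nothing measured on this change, the step from compound 1 to compound 3 is expected to be none beyond the scatter, a 1.1-fold lower number from compound 1 to compound 3 (0.06 log units; within the scatter). Compound 3 is estimated at 1.9 ug/mL, range 0.8 ug/mL to 4.5 ug/mL.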

Compound 3, half-maximal inhibitory concentration: 2.07 ug/mL
Compound 3: the middle estimate sits 1.1-fold (0.04 log units) below what was measured; low and high end bracket the measured number.
By their numbers in this assay, from the lowest: compounds 3, 2 and 1 (each within the scatter of the next).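

Among these compounds, exchanging 4-methylphenyl for 4-methoxyphenyl on the core of compound 1 gives a 1.1-fold lower number from compound 1 to compound 3 (0.02 log units; within the scatter) in this assay, the first one-place step. At this position, para to a large group, the added oxygen and the hydrogen-bond acceptor it counts as leave the number within the scatter. Nothing available explains this outcome.

Going by these compounds, whether an amine, a carboxylic acid or a longer chain at this position would move the number beyond the scatter remains open. Also open, on these data alone, is whether methoxy in place of methyl reads the same on another aromatic carbon.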